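Anilide in place of aryl ketone on a triazole thioether

A few compounds are considered here, and "the series" means these few. Any claim that something is new, unique, unknown or untested is made for them only; others in the source may bear on it.

Measured compounds:
compound 1, `COc1cc(-c2nnc(SCC(=O)c3ccc(F)cc3)n2N)cc(OC)c1OC` — 90400 nM
compound 2, `COc1ccc(C(=O)CSc2nnc(-c3cc(OC)c(OC)c(OC)c3)n2N)cc1` — > 100000 nM

Compound 1 and compound 2 share a core and differ only in a single aromatic substituent. In a functional assay on HepG2 cells (Homo sapiens) for antiproliferative activity, read by MTT assay, with a stated time of 48 h (on this read-out higher numbers stand for weaker inhibition and lower numbers for stronger inhibition), compound 1 gives 90400 nM. Compound 2 reaches only the limit of this assay, > 100000 nM, so no number stands for it. That limit is the limit of > 100000 nM in this assay, at which 1 of the 2 values shown sits. Among the compounds with values here, the one measured step, an at least 1.1-fold higher number from compound 1 to compound 2 (0.04 log units; that floor lies within the scatter), concerns a change on the distal aromatic ring and not the carbonyl carbon, so it does not speak directly to the change now at hand.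

Compound 3 is `COc1cccc(NC(=O)CSc2nnc(-c3cc(OC)c(OC)c(OC)c3)n2N)c1`. Relative to compound 2 the change is (3-methoxyphenyl)amino in place of 4-methoxyphenyl on a carbonyl carbon. Within the data shown here, with compound 2 at the limit and the only measured step lying within the scatter, compound 3 is expected near that same ceiling. The expected step is a number no higher from compound 2 to compound 3 (the limit leaves the size open). Compound 3 is therefore estimated at 100000 nM, within 40000 nM to 250000 nM.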

Compound 3, half-maximal inhibitory concentration: > 100000 nM
Compound 3 gave a limit, no number; the forecaster's own chance of this, stated with the estimate: 60%; the middle value lies on the limit itself.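

In this assay compound 3 gives > 100000 nM as a limit and not a number. Setting (3-methoxyphenyl)amino on the carbonyl carbon in place of 4-fluorophenyl gives an at least 1.1-fold higher number from compound 1 to compound 3 (0.04 log units; that floor lies within the scatter) and so the anilide, which carries a hydrogen-bond donor that the aryl ketones lack, brings no change that can be told apart from compound 1. The step involving the two limits cannot be read, and compound 3 joins compound 2 at the ceiling: the limit of > 100000 nM in this assay, at which 2 of the 3 values shown sit.

With only compound 1 giving a number, the compounds shown do not tell how far the carbonyl carbon can carry activity. From the compounds shown here alone, whether a piperazine on that carbon, or a carboxylic acid on the aromatic ring of the anilide, would give a measurable value in this assay stays open.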